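Replacing chloro with a larger piperazinyl group

A few compounds are considered here, and "the series" means these few. Any claim that something is new, unique, unknown or untested is made for them only; others in the source may bear on it.

Compound 1 `Cn1c(-c2ccc(NC(=O)CCl)cc2)nc(-c2ccccc2)c1-c1ccccc1` is the starting point. For the measured compounds named here, in a functional assay on MCF7 cells (Homo sapiens) for cytotoxicity, read by MTT assay, with a stated time of 24 h, tested at 6.4 ug/mL (on this read-out higher numbers stand for a stronger effect at the one concentration tested and lower numbers for a weaker effect), compound 1 gives 14.2%, the lowest of the two numbers measured so far. Compound 2 `CN1CCN(CC(=O)Nc2ccc(-c3nc(-c4ccccc4)c(-c4ccccc4)n3C)cc2)CC1`, which differs only at the saturated chain carbon bound to the carbonyl carbon, gives 28.6% in this assay, and the step of a number 14.4 percentage points higher from compound 1 to compound 2 (beyond the scatter) shows what a 4-methylpiperazin-1-yl in place of chloro did at that place. The unmeasured compound 3 `CN(C)/C=C/N1CCN(CC(=O)Nc2ccc(-c3nc(-c4ccccc4)c(-c4ccccc4)n3C)cc2)CC1` carries the related change (4-(2-(dimethylamino)ethenyl)piperazin-1-yl in place of chloro on a saturated chain carbon bound to a carbonyl carbon). Going by the values given here, only the step from compound 1 to compound 2 bears on this, since both changes put a piperazin-1-yl group where the chloro stood; the group on compound 3 is larger, and nothing measured shows how that further part acts. A step in the same direction and of similar size is therefore expected, a number 15.8 percentage points higher from compound 1 to compound 3 (beyond the scatter). For compound 3 the estimate in this assay is 30%, with a range from 12% to 50%.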

Compound 3, a percentage reported as activity, at one concentration (the size of the read-out at that concentration, not a potency): 11.1%
Estimate against measurement, compound 3: 18.9 percentage points above, outside the stated range (below it).
By their numbers in this assay, from the lowest: compounds 3 and 1 (each within the scatter of the next); then compound 2.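

In this assay the result is a number 3.1 percentage points lower from compound 1 to compound 3 (within the scatter) and so a piperazin-1-yl group in place of chloro on this saturated chain carbon does not by itself bring a higher number. What stands on the ring amine nitrogen decides the outcome at this place, since 2-(dimethylamino)ethenyl in place of methyl gives a number 17.5 percentage points lower from compound 2 to compound 3 (beyond the scatter) and the gain seen with the 4-methylpiperazin-1-yl group does not carry over. No measurement on hand accounts for this difference.

Going by these compounds, it remains open whether the double bond or the dimethylamino end of the new group goes with the lower number, which a saturated 2-(dimethylamino)ethyl chain on that nitrogen could separate. An unsubstituted piperazine or a morpholine on the chain carbon would show how much depends on the methyl group itself.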